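The source may report more compounds than this note shows. Statements on the series, on what has been measured and on what is new or still open speak of the compounds shown alone.

Measured compounds in a toxicity assay on MT4 cells (Homo sapiens) for cytotoxicity, read by MTT assay, with a stated time of 5 days; a higher number here means that more compound is tolerated, a lower number that less compound is tolerated:
compound 1 `Cc1cnc(Nc2ccc(C#N)cc2)nc1Nc1c(F)cc(-c2cccs2)cc1F` gives 8000 nM
compound 2 `Cc1cnc(Nc2ccc(C#N)cc2)nc1Nc1c(F)cc(-c2ccnc(F)c2)cc1F` gives 167000 nM
compound 3 `Cc1cc(-c2ccco2)cc(C)c1Nc1ccnc(Nc2ccc(C#N)cc2)n1` gives 1700 nM

Compound 3 stands at the lowest of the three numbers in this assay. Its nearest neighbour is compound 1, whose number is higher by a step beyond the scatter, and the furthest is compound 2, which stands far higher still. Compound 4 `Cc1cc(-c2cc(F)nc(F)c2)cc(C)c1Nc1ccnc(Nc2ccc(C#N)cc2)n1` is not yet measured in this assay. It differs from compound 3 in one place: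

2,6-difluoropyridin-4-yl in place of furan-2-yl on an aromatic carbon

Going by the values given here, one measured step bears on this change. It is a 21-fold higher number from compound 1 to compound 2 (1.32 log units; beyond the scatter), a five-membered aromatic ring with one hetero atom giving way to a fluorine-bearing pyridinyl on the same kind of aromatic carbon. The present change is of the same sort, a furan-2-yl giving way to a 2,6-difluoropyridin-4-yl, on a different core with two methyl groups; that core contributes nothing measured of its own. Among the compounds with values here, a large step upward in this assay is therefore expected, though the single precedent leaves its size uncertain. For compound 4 the expected step is a 10-fold higher number from compound 3 to compound 4 (1.00 log units; beyond the scatter). Compound 4 is estimated at 17000 nM, with a likely range from 5000 nM to 60000 nM.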

Compound 4, half-maximal cytotoxic concentration: 6300 nM
Compound 4: middle estimate off by 2.7-fold (0.43 log units), on the high side; low and high end bracket the measured number.
By their numbers in this assay, from the lowest: compound 3; then compounds 4 and 1 (each within the scatter of the next); then compound 2.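

In this assay, the change from furan-2-yl to 2,6-difluoropyridin-4-yl on the aromatic carbon para to a large group gives a 3.7-fold higher number from compound 3 to compound 4 (0.57 log units; beyond the scatter), so the upward direction of a 21-fold higher number from compound 1 to compound 2 (1.32 log units; beyond the scatter) recurs on a second core. A fluorine-bearing pyridinyl in place of a five-membered aromatic ring with one hetero atom goes with a higher number in both pairs, and neither pair goes against this, but the step on the dimethyl-substituted core is the smaller of the two and the size does not carry over. The two pairs differ in the leaving ring, the entering ring and the core, and the data cannot assign the difference in size to any one of these; nothing at hand gives a cause for either step.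

Still open, going by these compounds, is how much of the step belongs to the fluorine atoms, which a plain pyridin-4-yl on the core of compound 3 would test. Also open, on these data alone, is whether a non-aromatic group at this place, such as morpholine or a short alkyl amine, would follow the same direction.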